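The compounds below may be only part of what the source reports. "The series", "measured", "known", "first", "only" and "open" are said of these compounds alone.

Measured so far in an assay on A10 cells for antagonist activity at Endothelin-1 receptor (Rattus norvegicus); on this read-out higher numbers stand for weaker inhibition and lower numbers for stronger inhibition:
compound 1 `COc1ccccc1C(Oc1cc(OCc2ccsc2)ccc1C#N)C(=O)O`: compound 1 gives 529 nM
compound 2 `N#Cc1ccc(OCc2ccsc2)cc1OC(C(=O)O)c1ccccc1C(F)(F)F`: compound 2 gives 53 nM
compound 3 `N#Cc1ccc(OCc2ccsc2)cc1OC(C(=O)O)c1ccoc1`: compound 3 gives 2850 nM

Compound 3 gives the highest number of the three. Its nearest neighbour is compound 1, a 5.4-fold higher number from compound 1 to compound 3 (0.73 log units; beyond the scatter); the gap to compound 2 is wider still, a 54-fold higher number from compound 2 to compound 3 (1.73 log units; beyond the scatter). Both of those steps swap the group on the saturated chain carbon bound to a carbonyl carbon and an oxygen on an aromatic ring, and both show that the group at that position can move the number well beyond the scatter. The step of a 10-fold lower number from compound 1 to compound 2 (1.00 log units; beyond the scatter) changes a substituent elsewhere and does not bear on the present change.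

Compound 4 `N#Cc1ccc(OCc2ccsc2)cc1OC(C(=O)O)c1ccco1` differs from compound 3 only at that position: furan-2-yl in place of furan-3-yl on a saturated chain carbon bound to a carbonyl carbon and an oxygen on an aromatic ring. Among the measured compounds shown here, no measured pair sets a furan-3-yl against a furan-2-yl, or any two isomers of one ring against each other, so nothing fixes the size or direction of this step. The steps into compound 3 show only that a furan-3-yl gives a higher number than either the 2-methoxyphenyl of compound 1 or the 2-(trifluoromethyl)phenyl of compound 2. The working expectation is therefore a number close to that of compound 3, with no step beyond the scatter in this assay. Compound 4 is expected at 2500 nM, within 800 nM to 8000 nM. That expectation means a 1.1-fold lower number from compound 3 to compound 4 (0.06 log units; within the scatter), with wide uncertainty in either direction.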

Compound 4, half-maximal inhibitory concentration: 2400 nM
Compound 4: middle estimate off by 1.0-fold (0.02 log units), on the high side; low and high end bracket the measured number.
By their numbers in this assay, from the lowest: compound 2; then compound 1; then compounds 4 and 3 (each within the scatter of the next).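

In this assay, furan-2-yl in place of furan-3-yl on the saturated chain carbon gives a 1.2-fold lower number from compound 3 to compound 4 (0.07 log units; within the scatter), so this first pair of ring isomers at the position stands within the scatter and shows no order between the two furans. The large gap to the substituted phenyl groups is not tied to one furan isomer: the series gives a 45-fold higher number from compound 2 to compound 4 (1.66 log units; beyond the scatter) and a 4.5-fold higher number from compound 1 to compound 4 (0.66 log units; beyond the scatter), both beyond the scatter and in the same direction as the steps into compound 3. No measured evidence accounts for any of these steps.

Still open, going by these compounds, is whether an unsubstituted phenyl or a thiophen-3-yl at this position would stand with the two furans or with the 2-methoxyphenyl and 2-(trifluoromethyl)phenyl groups, which would help separate the contribution of the ring itself from that of its substituent. Also open, on these data alone, is whether the isomers of another ring, such as pyridin-2-yl and pyridin-3-yl, would likewise fall within the scatter of each other, or whether this holds only for the furan pair.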